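A ring swap on compound 2

This account rests on a few compounds, and the source may have more. Where it says the series, first, only, none or still open, it means among the compounds named here.

Of the compounds shown here, two with a shared core have so far been tested in an ADME assay on cells (Homo sapiens) for cytotoxicity, read by resazurin assay, with a stated time of 5 days; on this read-out lower numbers stand for higher toxicity in this test and higher numbers for lower toxicity in this test. Compound 1 `COc1ccc(-c2nc(CS(=O)(=O)c3cccc(Cl)c3)nc3ccsc23)cn1` gives > 10000 nM there, which is a limit of the assay and not a number. Within the data shown here, compound 2 `O=S(=O)(Cc1nc(-c2ccc(F)nc2)c2sccc2n1)c1cccc(Cl)c1` gives 40000 nM and so holds the only true number in the set, with nothing yet to rank it against.

The next structure is compound 3 `O=S(=O)(Cc1nc(-c2cccs2)c2sccc2n1)c1cccc(Cl)c1`. It puts thiophen-2-yl in place of the 6-fluoropyridin-3-yl of compound 2, on an aromatic carbon next to the ring nitrogen, and the counted difference is thiophen-2-yl in place of 6-fluoropyridin-3-yl on an aromatic carbon here.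

Among the measured compounds shown here, only one measured step exists, a step that the limit leaves unreadable from compound 1 to compound 2 and it concerns another swap, fluoro in place of methoxy on an aromatic carbon. Its size is lost to the limit of > 10000 nM in this assay, at which 1 of the 2 values shown sits, and it offers no guide to size or direction.

For the measured compounds named here, the only number to start from is compound 2 at 40000 nM and no readable step moves it either way. The expected step is a 1.3-fold lower number from compound 2 to compound 3 (0.12 log units; within the scatter) and nothing beyond the usual scatter is expected. Compound 3 is expected at 30000 nM with 10000 nM to 80000 nM as the estimated range.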

Compound 3, half-maximal cytotoxic concentration: > 50000 nM
Compound 3 ended at the assay's limit (the forecaster's own chance of this, stated with the estimate: 35%); at least 1.6-fold (0.22 log units) between middle value and limit.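

In this assay compound 3 gives > 50000 nM, which is a limit of the assay and not a number. At this position on the shared core, a six-membered aromatic ring, 6-fluoropyridin-3-yl, can give way to a five-membered one, thiophen-2-yl, with no sign of higher toxicity in this test: the result is an at least 1.2-fold higher number from compound 2 to compound 3 (0.09 log units; that floor lies within the scatter), and that floor lies within the usual scatter, so on its own it does not prove a real change. The true size of the step stays unknown because compound 3 sits at a limit: the limit of > 50000 nM in this assay, at which 1 of the 3 values shown sits.

The steps that involve compound 1 cannot be read, so the 6-methoxypyridin-3-yl compound cannot be ranked against the other two. From the compounds shown here alone, all three compounds carry an aromatic ring at this position, and it remains open whether an amine, a carboxylic acid or a longer chain there would bring the number down to a clearly lower value.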